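Methoxyphenyl change on the carbonyl carbon: compound 3

The source may hold more compounds than are shown below. What is called first, only, known or untested is meant among the compounds shown, and "the series" means these compounds.

In an ADME assay on cells (Lymphocyte, Homo sapiens) for cytotoxicity, read by MTT assay, with a stated time of 48 h (on this read-out higher numbers stand for weaker inhibition and lower numbers for stronger inhibition), compound 1 (`COC(=O)/C(=C\c1ccc(OC(=O)c2ccc(OC)cc2)cc1)Sc1ccnc2cc(Cl)ccc12`) gives 63500 nM. Compound 2 (`COC(=O)/C(=C\c1ccc(OC(=O)c2ccccc2OC)cc1)Sc1ccnc2cc(Cl)ccc12`) gives > 100000 nM, which is a limit of the assay and not a number. Compound 2 therefore has no exact position on the scale. Compound 3 (`COC(=O)/C(=C\c1ccc(OC(=O)c2ccc(OC)c(OC)c2)cc1)Sc1ccnc2cc(Cl)ccc12`) has 3,4-dimethoxyphenyl in place of 2-methoxyphenyl on a carbonyl carbon. For the measured compounds named here, only one measured step bears on this change: an at least 1.5-fold higher number from compound 1 to compound 2 (0.19 log units; that floor lies within the scatter), with 2-methoxyphenyl in place of 4-methoxyphenyl on a carbonyl carbon. Its size is known only as a floor. The 3,4-dimethoxyphenyl name retains the 4-methoxy pattern, so compound 1 at 63500 nM serves as the working reference. The expected change is an at least 1.4-fold lower number from compound 2 to compound 3 (0.15 log units; that floor lies within the scatter), leaning slightly towards a lower number but not expected to exceed the scatter. For compound 3 the estimate is 70000 nM, with an expected range of 30000 nM to 150000 nM.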

Compound 3, half-maximal inhibitory concentration: 51100 nM
Beside the measured number, compound 3's estimate is 1.4-fold (0.14 log units) above it; the range from low to high includes it.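

In this assay the change from 2-methoxyphenyl to 3,4-dimethoxyphenyl on a carbonyl carbon can be read only as a floor (an at least 1.9-fold lower number from compound 2 to compound 3 (0.29 log units; that floor lies within the scatter)). Compound 2 carries a limit and not a number: the limit of > 100000 nM in this assay, at which 1 of the 3 values shown sits. Methoxy in place of hydrogen on an aromatic carbon adds the first step at this position with an exact size, and it stays within the scatter (a 1.2-fold lower number from compound 1 to compound 3 (0.09 log units; within the scatter)).

Going by these compounds, the true size of the step away from 2-methoxyphenyl remains open, and it cannot be said whether that step would pass beyond the scatter. Also open, on these data alone, is whether an amine or a carboxylic acid on this aromatic ring, in place of the methoxy groups, would move the number beyond the scatter.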